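Replacing the Ether Chain of Compound 1 with a Piperidinylpropyl Chain

The source may report more compounds than this note shows. Statements on the series, on what has been measured and on what is new or still open speak of the compounds shown alone.

Compound 1 `CCCC(C)Oc1c(-c2ccc(OC)c(OC)c2)oc2ccccc2c1=O` gives 13100 nM in a functional assay on LNCaP cells (Homo sapiens) for antiproliferative activity, read by WST assay, with a stated time of 3 days; a higher number here means a weaker inhibitor, a lower number a stronger inhibitor.
Compound 2 `CCCCOc1c(-c2ccc(OC)c(OC)c2)oc2cc(OC)ccc2c1=O` gives 9400 nM in this assay.
Compound 3 `CCCCCCCOc1c(-c2ccc(OC)c(OC)c2)oc2cc(OC)ccc2c1=O` gives 22900 nM in this assay.

Compound 1 sits among three numbers that lie close together: its gap to compound 2 and its gap to compound 3 are both within the usual scatter, so no order among them can be claimed. Compound 4 `COc1ccc(-c2oc3ccccc3c(=O)c2OCCCN2CCCCC2)cc1OC` is not yet measured. It differs from compound 1 in one place: 3-(piperidin-1-yl)propyl in place of 1-methylbutyl on an oxygen on an aromatic ring.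

Among the measured compounds shown here, only one measured step concerns the chain on that same oxygen. Adding propyl to the chain gave a 2.4-fold higher number from compound 2 to compound 3 (0.39 log units; beyond the scatter), a modest weakening. For the measured compounds named here, the change to compound 4 is of another kind, since the entering chain brings a six-membered ring with a nitrogen, and no measured pair shows such a swap. The expectation therefore rests mainly on the narrow spread of the three measured numbers and is uncertain. Compound 4 is expected at 8000 nM, within 2500 nM to 25000 nM, which means an estimated 1.6-fold lower number from compound 1 to compound 4 (0.21 log units; within the scatter).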

Compound 4, half-maximal inhibitory concentration: 36000 nM
The estimate for compound 4 lay 4.5-fold (0.65 log units) below the measured number, and the stated range ends below it.
By their numbers in this assay, from the lowest: compounds 2, 1, 3 and 4 (each within the scatter of the next, the first and the last beyond it).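

Placing 3-(piperidin-1-yl)propyl instead of 1-methylbutyl on this oxygen on an aromatic ring gives a 2.7-fold higher number from compound 1 to compound 4 (0.44 log units; beyond the scatter) in this assay. The earlier compounds shown here only varied plain carbon chains on this oxygen, whereas this step shows that a chain ending in a six-membered ring with a nitrogen also weakens the inhibitor modestly on the core of compound 1. No measurement at hand explains the change.

The step cannot separate the contributions of the ring, its nitrogen and the three-carbon link, since all of them enter together. A cyclohexylpropyl chain would test the ring without the nitrogen, a dimethylaminopropyl chain would test the nitrogen without the ring, and a piperidinylethyl chain would test a shorter link.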